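Fluoro Gives Way to Ethylcarbamoyl on an Inactive Compound

A few compounds are considered here, and "the series" means these few. Any claim that something is new, unique, unknown or untested is made for them only; others in the source may bear on it.

In a functional assay on A549 cells (Homo sapiens) for antiproliferative activity, read by CCK-8 assay, with a stated time of 72 h (on this read-out lower numbers stand for stronger inhibition of growth and higher numbers for weaker inhibition of growth), compound 1 (`CC[C@@H]1C(=O)N(C)c2cnc(-n3ccc4ccccc43)nc2N1C1CCCC1`) gives 57500 nM as its only numerical result. Compound 2 (`CCC1C(=O)N(C)c2cnc(-n3ccc4cc(F)ccc43)nc2N1c1ccn(C)n1`) is recorded just as "not active" (no number reported) in that test, so it has no single number and its standing can be told only in those words. Compound 3 (`CCNC(=O)c1ccc2c(ccn2-c2ncc3c(n2)N(c2ccn(C)n2)C(CC)C(=O)N3C)c1`) has not yet been measured. The structural change is ethylcarbamoyl in place of fluoro on an aromatic carbon and it puts ethylcarbamoyl in place of fluoro on an aromatic carbon of a six-membered aromatic ring of carbon only. Among the compounds with values here, no measured pair shows this change, so a moderate step towards stronger inhibition of growth in this assay is only an expectation, and compound 3 may also stay without a number. Within the data shown here, the one available anchor is compound 1 at 57500 nM in the same test. Compound 3 is estimated at 20000 nM within an expected range of 3000 nM to 80000 nM if a number is reported at all.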

Compound 3, concentration for 50% growth inhibition: 21700 nM
Estimate against measurement, compound 3: 1.1-fold (0.04 log units) below, within the range that was stated.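

In this assay compound 2 stands only as "not active" while compound 3 gives 21700 nM as a number, so no step can be read between them. The compounds shown leave open what ethylcarbamoyl in place of fluoro does on its own. No supporting evidence bears on this result.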